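The compounds below may be only part of what the source reports. "The series", "measured", "known", "first", "only" and "open" are said of these compounds alone.

Compound 1 `CNC(=O)c1cc(Oc2ccc(NC(=O)c3cc4cccnc4n(-c4ccccc4F)c3=O)cc2)ccn1` is the starting point. Among the measured compounds shown here, in a functional assay on A549 cells (Homo sapiens) for antiproliferative activity, read by MTT assay, with a stated time of 72 h (a lower number here means a stronger inhibitor, a higher number a weaker inhibitor), compound 1 gives 610 nM, the lowest of the two numbers known so far, while compound 2 `CNC(=O)c1cc(Oc2ccc(NC(=O)c3cc4cccnc4n(-c4ccc(Br)cc4)c3=O)cc2)ccn1` gives 1050 nM. Compound 3 `CNC(=O)c1cc(Oc2ccc(NC(=O)c3cc4cccnc4n(-c4ccc(Br)cc4F)c3=O)cc2)ccn1` differs from compound 1 by bromo in place of hydrogen on an aromatic carbon. For the measured compounds named here, the only comparison that bears on this change is a 1.7-fold higher number from compound 1 to compound 2 (0.24 log units; within the scatter), a swap on the same ring that stayed within the scatter. A similar outcome is expected here, so the step of a 1.2-fold higher number from compound 1 to compound 3 (0.09 log units; within the scatter) is estimated to be small. Compound 3 is therefore estimated at 750 nM, with a range from 350 nM to 1600 nM.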

Compound 3, half-maximal inhibitory concentration: 1420 nM
Compound 3: the middle estimate sits 1.9-fold (0.28 log units) below what was measured; the range from low to high includes it.
By their numbers in this assay, from the lowest: compounds 1, 2 and 3 (each within the scatter of the next, the first and the last beyond it).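

Bromo in place of hydrogen on the ring of compound 1 gives the first step here that lies beyond the scatter, though a modest one (a 2.3-fold higher number from compound 1 to compound 3 (0.37 log units; beyond the scatter)). Fluoro in place of hydrogen on the ring of compound 2 stays within the scatter (a 1.4-fold higher number from compound 2 to compound 3 (0.13 log units; within the scatter)), so with bromo present, this fluoro group makes no clear difference. Nothing available explains these numbers.

Only halogens appear at this place on the ring so far. Going by these compounds, whether an amine or a carboxylic acid there would give a lower or a higher number remains open.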